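Moving the Methyl on the Triazole of Compound 3

A few compounds are considered here, and "the series" means these few. Any claim that something is new, unique, unknown or untested is made for them only; others in the source may bear on it.

Measured compounds:
compound 1, `COc1ccc(OC)c(/C=N/NC(=O)Nc2ccc(Oc3ccnc(-c4nncn4CCN(C)C)c3)c(F)c2)c1`, gives 6400 nM in a functional assay on U-87MG ATCC cells (Homo sapiens) for cytotoxicity, read by MTT assay, with a stated time of 72 h; a higher number here means a weaker inhibitor, a lower number a stronger inhibitor
compound 2, `CN(C)CCn1cnnc1-c1cc(Oc2ccc(NC(=O)N/N=C/c3ccccc3)cc2F)ccn1`, gives 2250 nM in this assay
compound 3, `Cn1ncnc1-c1cc(Oc2ccc(NC(=O)N/N=C/c3ccccc3)cc2F)ccn1`, reaches only a limit of this assay, > 100000 nM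

Compound 3 therefore stands at the weak end of the three: its value is a limit, not a number, and it sits at the limit of > 100000 nM in this assay, at which 1 of the 3 values shown sits. Compound 4, `Cn1cnnc1-c1cc(Oc2ccc(NC(=O)N/N=C/c3ccccc3)cc2F)ccn1`, has the same atoms as compound 3 joined differently: 4-methyl-4H-1,2,4-triazol-3-yl in place of 1-methyl-1H-1,2,4-triazol-5-yl on an aromatic carbon.

Two measured steps frame this change. The step of a 2.8-fold lower number from compound 1 to compound 2 (0.45 log units; beyond the scatter) is modest and concerns the other end of the molecule. The step of an at least 44-fold higher number from compound 2 to compound 3 (1.64 log units; beyond the scatter) is large, but it changes two things at once, the methyl in place of the 2-(dimethylamino)ethyl chain and the triazole connectivity. Compound 4 keeps the methyl of compound 3 while taking the 4H-1,2,4-triazol-3-yl connectivity of compound 2, so it separates the two parts of that large step. The account expects compound 4 to land between compound 2 and compound 3, with a step of an at least 3.3-fold lower number from compound 3 to compound 4 (0.52 log units; beyond the scatter) downward, though a result that again sits at the limit cannot be ruled out. Compound 4 is thus estimated at 30000 nM, with a range from 5000 nM to 150000 nM.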

Compound 4, half-maximal inhibitory concentration: 36300 nM
Compound 4: the middle estimate sits 1.2-fold (0.08 log units) below what was measured; the range from low to high includes it.
By their numbers in this assay, from the lowest: compound 2; then compound 1; then compound 4. At a limit, above all of these: compound 3.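

With the methyl held fixed, the connectivity of the triazole alone shifts the result in this assay: 4-methyl-4H-1,2,4-triazol-3-yl in place of 1-methyl-1H-1,2,4-triazol-5-yl on an aromatic carbon gives an at least 2.7-fold lower number from compound 3 to compound 4 (0.44 log units; beyond the scatter). That step is only a minimum, and how the earlier combined step divides between connectivity and chain stays unsettled, since compound 3 is held at a limit of the assay: the limit of > 100000 nM in this assay, at which 1 of the 4 values shown sits. The chain also counts on its own, for with the connectivity shared, the change from compound 2 gives a 16-fold higher number from compound 2 to compound 4 (1.21 log units; beyond the scatter), as hydrogen takes the place of (dimethylamino)methyl on a saturated chain carbon bound to an aromatic nitrogen.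

The compounds shown leave open whether the dimethylamino group or the length of the chain carries this difference, a question that a plain ethyl chain, a 2-aminoethyl chain or a 2-(morpholin-4-yl)ethyl chain on the same triazole would address. They also leave open whether a 2-(dimethylamino)ethyl chain on the connectivity of compound 3 would give a number within the range of this assay.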